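A Chloro Substituent on the Core of Compound 1

A few compounds are considered here, and "the series" means these few. Any claim that something is new, unique, unknown or untested is made for them only; others in the source may bear on it.

Compound 1 `FC(F)=C(F)CCSc1nccs1` was tested in a functional assay on MCF7 cells (Homo sapiens) for cytotoxicity, read by MTT assay, with a stated time of 48 h; on this read-out lower numbers stand for stronger inhibition and higher numbers for weaker inhibition. In this assay compound 1 gives > 120000 nM, which is a limit of the assay rather than a number. Compound 2 `O=S(=O)(CCC(F)=C(F)F)c1nc2ccc(OC(F)F)cc2[nH]1`, built on a different core, was tested in the same way. In this assay compound 2 gives > 120000 nM, again only a limit. Compound 1 thus stands at the limit of > 120000 nM in this assay, at which 2 of the 2 values shown sit, and no measured number places it against any other compound. Compound 3 `FC(F)=C(F)CCSc1ncc(Cl)s1` differs from compound 1 by chloro in place of hydrogen on an aromatic carbon. Among the compounds with values here, no step between measured compounds is available to set the size of such a change. The expected step is a number no higher from compound 1 to compound 3 (the limit leaves the size open), which is to say none beyond the scatter. Compound 3 is therefore estimated at 120000 nM in this assay, with a range from 60000 nM to 300000 nM, and it is expected that the result would most likely again be reported only as a limit.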

Compound 3, half-maximal inhibitory concentration: > 120000 nM
Compound 3: no number, only a limit; the forecaster's own chance of this, stated with the estimate: 80%; the middle value lies on the limit itself.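

Within the data shown here, compound 1 and compound 3 both give only a limit in this assay, so no step between them can be read: the limit of > 120000 nM in this assay, at which 3 of the 3 values shown sit. The compounds shown leave open whether chloro in place of hydrogen on an aromatic carbon changes cytotoxicity on the core of compound 1 at all.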